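The compounds below may be only part of what the source reports. "The series", "measured", "known", "first", "only" and "open" are said of these compounds alone.

Working notes on the series built on the core shown in compound 2 `O=C1/C(=C/c2ccc(Cl)cc2)CCC/C1=C\c1ccc([N+](=O)[O-])cc1`. In a functional assay on HL-60 cells (Homo sapiens) for cytotoxicity (on this read-out lower numbers stand for higher toxicity in this test and higher numbers for lower toxicity in this test), compound 2 gives 4100 nM. Compound 1 `COc1cc(/C=C2\CCC/C(=C\c3ccc([N+](=O)[O-])cc3)C2=O)ccc1O` carries a 4-hydroxy-3-methoxyphenyl on the same double-bonded chain carbon, and in this assay compound 1 gives 3400 nM. Compound 3 `COc1ccc(/C=C2\CC/C(=C\c3ccc([N+](=O)[O-])cc3)C2=O)cc1` has a smaller core together with a 4-methoxyphenyl. In this assay compound 3 reaches only > 400000 nM, which is a limit of the assay and not a number (the limit of > 400000 nM in this assay, at which 1 of the 3 values shown sits). Of the two numbers shown, compound 2 sits at one end with compound 1 nearest, the gap being a 1.2-fold higher number from compound 1 to compound 2 (0.08 log units; within the scatter), so the two are not separated beyond the scatter.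

Compound 4 `O=C1/C(=C/c2ccc(O)cc2)CCC/C1=C\c1ccc([N+](=O)[O-])cc1` has not yet been measured. Relative to compound 2 the change is hydroxy in place of chloro on an aromatic carbon. Within the data shown here, the only measured step that bears on this is the one from compound 1 to compound 2, in which a group containing a hydroxy gave way to a chloro with a 1.2-fold higher number from compound 1 to compound 2 (0.08 log units; within the scatter). Among the measured compounds shown here, compound 3 differs from compound 2 in two places and gives no usable step. The expected step is therefore a 1.0-fold lower number from compound 2 to compound 4 (0.01 log units; within the scatter), in this assay no change beyond the scatter. Compound 4 is estimated at 4000 nM, with a range from 1500 nM to 12000 nM.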

Compound 4, half-maximal cytotoxic concentration: 4400 nM
For compound 4 the middle estimate is 1.1-fold (0.04 log units) below the measured one; the range from low to high includes it.
By their numbers in this assay, from the lowest: compounds 1, 2 and 4 (each within the scatter of the next). At a limit, above all of these: compound 3.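

In this assay, hydroxy in place of chloro on this aromatic carbon gives a 1.1-fold higher number from compound 2 to compound 4 (0.03 log units; within the scatter) as a direct reading of the change, where the earlier step from compound 1 to compound 2 also involved the methoxy. Hydrogen in place of methoxy on an aromatic carbon can now be read alone as well and gives a 1.3-fold higher number from compound 1 to compound 4 (0.11 log units; within the scatter) with no change beyond the scatter. Compounds 1, 2 and 4 thus stay within the scatter across these three aryl groups on the shared core, and the hydroxy with its hydrogen-bond donor and acceptor is not told apart from the chloro, which has neither.

Going by these compounds, whether an amine, a carboxylic acid or a longer chain such as butoxy on the same aromatic carbon would also stay within the scatter of compound 2 remains open, as does whether any group at this place can move the read-out beyond it. The compounds shown give no measured basis for explaining why these exchanges leave the read-out within the scatter.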